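The source may report more compounds than this note shows. Statements on the series, on what has been measured and on what is new or still open speak of the compounds shown alone.

Measured in a functional assay on MCF7 cells (Homo sapiens) for antiproliferative activity, read by MTT assay, with a stated time of 48 h; on this read-out lower numbers stand for stronger inhibition and higher numbers for weaker inhibition:
- compound 1 `Cc1ccc(C(=O)/C=C/c2cc(Br)cc(Br)c2Oc2c([N+](=O)[O-])cc(C(F)(F)F)cc2[N+](=O)[O-])cc1`: 1.44 ug/mL
- compound 2 `COc1ccc(C(=O)/C=C/c2cc(Br)cc(Br)c2Oc2c([N+](=O)[O-])cc(C(F)(F)F)cc2[N+](=O)[O-])cc1`: 3.53 ug/mL
- compound 3 `O=C(/C=C/c1cc(Br)cc(Br)c1Oc1c([N+](=O)[O-])cc(C(F)(F)F)cc1[N+](=O)[O-])c1ccc(Cl)cc1`: 6.76 ug/mL

Compound 3 shares the weak end of this small set with the methoxy member, the gap being a 1.9-fold higher number from compound 2 to compound 3 (0.28 log units; within the scatter). Against the methyl member the gap is larger: a 4.7-fold higher number from compound 1 to compound 3 (0.67 log units; beyond the scatter). The remaining step in the set is a 2.5-fold higher number from compound 1 to compound 2 (0.39 log units; beyond the scatter).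

Next is compound 4 `O=C(/C=C/c1cc(Br)cc(Br)c1Oc1c([N+](=O)[O-])cc(C(F)(F)F)cc1[N+](=O)[O-])c1ccc(Br)cc1`, which differs from compound 3 in one place: bromo in place of chloro on an aromatic carbon. This is bromo in place of chloro on an aromatic carbon, para to a large group.

Among the measured compounds shown here, no measured step makes this exact exchange, so the evidence is indirect. All three measured steps are changes at this same place, and they are modest or lie within the scatter. The closest to compound 3 is a 1.9-fold higher number from compound 2 to compound 3 (0.28 log units; within the scatter). For the measured compounds named here, the data hold no second pair with a bromo at this place, so the direction of any shift is open.

In this assay, no step beyond the scatter is expected. The estimated step is a 1.1-fold lower number from compound 3 to compound 4 (0.05 log units; within the scatter). For compound 4 the expected value is 6 ug/mL, with an estimated range of 2.7 ug/mL to 13 ug/mL.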

Compound 4, half-maximal inhibitory concentration: 2.87 ug/mL
Compound 4: middle estimate off by 2.1-fold (0.32 log units), on the high side; the measured number falls inside the stated range.
By their numbers in this assay, from the lowest: compounds 1, 4, 2 and 3 (each within the scatter of the next, the first and the last beyond it).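

At this place, on an aromatic carbon para to a large group, exchanging one halogen for the other is enough to give a step beyond the scatter in this assay, with a 2.4-fold lower number from compound 3 to compound 4 (0.37 log units; beyond the scatter), although chloro and bromo count the same under heavy atoms, donors and acceptors. The bromo member also stays within the scatter of both non-halogen members, with a 1.2-fold lower number from compound 2 to compound 4 (0.09 log units; within the scatter) and a 2.0-fold higher number from compound 1 to compound 4 (0.30 log units; within the scatter), so the methyl, methoxy and bromo members are not separated from compound 4 here, and the halogens do not form one group at this place. Nothing in the data bears on the origin of the gap between the chloro and bromo members.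

Still open, on these data alone, is how fluoro, an amine, a carboxylic acid or a longer chain at this place would read in this assay, and whether the position would tolerate a plain hydrogen. Also open, as far as these compounds go, is whether the gap between chloro and bromo persists on a core carrying a change elsewhere, or in cells other than MCF7.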